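A few compounds are considered here, and "the series" means these few. Any claim that something is new, unique, unknown or untested is made for them only; others in the source may bear on it.

Values in a functional assay on A549 cells (Homo sapiens) for antiproliferative activity, read by MTT assay, with a stated time of 72 h; a higher number here means a weaker inhibitor, a lower number a stronger inhibitor:
- compound 1 `COc1cc2ncnc(Nc3cccc(Br)c3)c2cc1OCCCN1CCNCCNCC1`: 34300 nM
- compound 2 `COc1cc2ncnc(Nc3ccc(Cl)c(C(F)(F)F)c3)c2cc1OCCCN1CCNCCNCC1`: 6230 nM
- compound 3 `COc1cc2ncnc(Nc3cccc(I)c3)c2cc1OCCCN1CCNCCNCC1`: not yet measured

Of the two measured compounds, compound 2 has the lower number, at 6230 nM. The next change is 3-iodophenyl in place of 4-chloro-3-(trifluoromethyl)phenyl on a nitrogen on an aromatic ring. For the measured compounds named here, only one measured step bears on it: a 5.5-fold lower number from compound 1 to compound 2 (0.74 log units; beyond the scatter). That step introduced the group now leaving, so removing it should partly or wholly reverse the gain. The expectation rests on the 3-bromophenyl of compound 1 at 34300 nM, the closest measured match to 3-iodophenyl. A modest rise of similar size is expected in this assay, estimated as a 4.0-fold higher number from compound 2 to compound 3 (0.60 log units; beyond the scatter). The estimate for compound 3 is 25000 nM, with an expected range of 10000 nM to 60000 nM.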

Compound 3, half-maximal inhibitory concentration: 26200 nM
Beside the measured number, compound 3's estimate is 1.0-fold (0.02 log units) below it; the measured number falls inside the stated range.
By their numbers in this assay, from the lowest: compound 2; then compounds 3 and 1 (each within the scatter of the next).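

In this assay the aniline exchange gives a 4.2-fold higher number from compound 2 to compound 3 (0.62 log units; beyond the scatter) and so the advantage of compound 2 is lost with 3-iodophenyl as well as with 3-bromophenyl. Exchanging the halogen alone gives a 1.3-fold lower number from compound 1 to compound 3 (0.12 log units; within the scatter) and so iodo and bromo on this aromatic carbon are not told apart in this series. Still open, on these data alone, is whether the chloro or the trifluoromethyl carries the advantage of compound 2, and how a nitrile or a methoxy on this aromatic ring would compare. No measurement here accounts for either step.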